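The compounds below may be only part of what the source reports. "The series", "measured", "known", "first", "only" and "open" are said of these compounds alone.

Measured compounds and their values in an ADME assay on HepG2 2.2.15 cells (Homo sapiens) for cytotoxicity, read by MTT assay, with stated times of 48 h and 9 days; a lower number here means that less compound is tolerated, a higher number that more compound is tolerated:

Compound 1 `COc1ccc2c(=O)c(/C=C/C(=O)Nc3cccc(C)c3)coc2c1`: 554000 nM
Compound 2 `O=C(/C=C/c1coc2cc(O)ccc2c1=O)NCc1ccccc1`: 436000 nM
Compound 3 `COc1ccc2c(=O)c(/C=C/C(=O)NCc3ccccc3F)coc2c1`: 146000 nM

Among these three, compound 3 gives the lowest number in this assay. Its nearest neighbour is compound 2, and the furthest is compound 1; both gaps lie beyond the scatter, so compound 3 is the one of the three of which least is tolerated.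

The step under study leads to compound 4 `COc1ccc2c(=O)c(/C=C/C(=O)Nc3ccc(C)cc3)coc2c1`, which is not yet measured. It differs from compound 3 in one place: 4-methylphenyl in place of 2-fluorobenzyl on an amide-type nitrogen.

Within the data shown here, one measured step bears on this change. Going from compound 1 to compound 3, the same amide-type nitrogen carried 2-fluorobenzyl instead of 3-methylphenyl, and the number fell: a 3.8-fold lower number from compound 1 to compound 3 (0.58 log units; beyond the scatter). The change to compound 4 runs the other way, putting a methylphenyl group back onto that nitrogen, with the methyl now at the 4-position of the ring. On that basis a modest rise in this assay is expected, roughly undoing the earlier drop, so that compound 4 should end near compound 1. The expected step is a 3.1-fold higher number from compound 3 to compound 4 (0.49 log units; beyond the scatter). For compound 4 the estimate is 450000 nM, within a range from 200000 nM to 900000 nM.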

Compound 4, half-maximal cytotoxic concentration: 979000 nM
The estimate for compound 4 lay 2.2-fold (0.34 log units) below the measured number; measured number above the stated range.
By their numbers in this assay, from the lowest: compound 3; then compounds 2, 1 and 4 (each within the scatter of the next, the first and the last beyond it).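

In this assay, 4-methylphenyl in place of 2-fluorobenzyl on the amide-type nitrogen gives a 6.7-fold higher number from compound 3 to compound 4 (0.83 log units; beyond the scatter) and so sets compound 3 apart from both methylphenyl compounds on the shared core, not only from the 3-methylphenyl one. The two methylphenyl groups are not themselves separated: 4-methylphenyl in place of 3-methylphenyl gives a 1.8-fold higher number from compound 1 to compound 4 (0.25 log units; within the scatter) and that step lies within the usual scatter, so on these two compounds the place of the methyl on the ring makes no difference that can be read. No measurement offered here accounts for why the number shifts with the group on this nitrogen.

The compounds shown leave open whether the lower number of compound 3 goes with the fluorine or with the benzyl link, as the shared core carries no 2-fluorophenyl group on this nitrogen to tell the two apart. They also leave open how a ring bearing an amine or a carboxylic acid in place of the methyl, or a longer chain on the same nitrogen, would stand in this assay.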